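This account rests on a few compounds, and the source may have more. Where it says the series, first, only, none or still open, it means among the compounds named here.

Measured so far:

Compound 1, `O=C(NC/C=C1\CCCc2cnn(-c3ccc(C(F)(F)F)cc3)c21)NS(=O)(=O)c1cc(Cl)c(Cl)s1`, in an assay on isolated protein for displacement of a labelled ligand from prostaglandin E2 receptor EP3 subtype (Homo sapiens), read by scintillation counting, with a stated time of 2 h (a lower number here means a stronger inhibitor, a higher number a weaker inhibitor), gives 0.4 nM.
Compound 2, `COc1ccc(S(=O)(=O)NC(=O)NC/C=C2\CCCc3cnn(Cc4ccc(Cl)cc4Cl)c32)cc1`, in this assay gives 10 nM.
Compound 3, `Cc1nc(C)c(S(=O)(=O)NC(=O)NC/C=C2\CCCc3cnn(Cc4ccc(Cl)cc4Cl)c32)s1`, in this assay gives 2 nM.

Compound 1 has the lowest number of the three, with compound 3 nearer to it and compound 2 furthest away. The one step shown among the measured compounds, a 5.0-fold lower number from compound 2 to compound 3 (0.70 log units; beyond the scatter), concerns the group on the sulfonyl sulfur at the other end of the shared core and leaves the aryl group on the pyrazole nitrogen untouched.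

Compound 4, `CS(=O)(=O)c1ccc(-n2ncc3c2/C(=C/CNC(=O)NS(=O)(=O)c2cc(Cl)c(Cl)s2)CCC3)cc1`, differs from compound 1 at that aryl group: methylsulfonyl in place of trifluoromethyl on an aromatic carbon. No measured step touches this position, so nothing among the shown pairs bears directly on the change; the only guide is that the shared core with the dichlorothiophene sulfonyl end has so far given the lowest number. Within the data shown here, since an exchange of this kind at a distant position has no precedent here, a modest drift toward a higher number is expected rather than a large jump, and compound 4 is estimated at 2 nM, within 0.4 nM to 10 nM, which means an expected step of a 5.0-fold higher number from compound 1 to compound 4 (0.70 log units; beyond the scatter).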

Compound 4, inhibition constant: 1 nM
The estimate for compound 4 lay 2.0-fold (0.30 log units) above the measured number; measured number inside the range.
By their numbers in this assay, from the lowest: compound 1; then compounds 4 and 3 (each within the scatter of the next); then compound 2.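

In this assay, among these compounds, the first measured change at this position, methylsulfonyl in place of trifluoromethyl on the aromatic carbon, gives a 2.5-fold higher number from compound 1 to compound 4 (0.40 log units; beyond the scatter) and so has a real but modest effect on the number. The two groups have the same count of heavy atoms, yet methylsulfonyl has hydrogen-bond acceptors and double bonds that trifluoromethyl lacks, and even with this exchange compound 4 still gives 1 nM in this assay, so this place accepts a quite different group without a large jump in the number. No measurement shown here explains why the number moves by this amount.

Among the compounds shown here, with only two groups compared at this place, it remains open how a primary amine, a carboxylic acid or a longer chain such as n-butyl would behave there, and a trend cannot be drawn from a single step. From the compounds shown here alone, compound 2 and compound 3 differ from compound 1 in more than one place, so it is also open whether the same exchange would give a similar step with another group on the sulfonyl sulfur.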